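One added methyl in a level solubility series

This account rests on a few compounds, and the source may have more. Where it says the series, first, only, none or still open, it means among the compounds named here.

In a physicochemical assay for solubility, at pH 1.1 (a higher number here means a more soluble compound, a lower number a less soluble compound), compound 1 (`CCCN(Cc1ccc(OCCN2C(=O)CCC2=O)c(C)c1)[C@@H](CC(=O)O)c1ccc(Cl)cc1`) gives 3000000 nM, compound 2 (`Cc1cc(CN(CC2CCCC2)C(CC(=O)O)c2ccc(Cl)cc2)ccc1OCCN1C(=O)CCC1=O`) gives 3000000 nM, and compound 3 (`Cc1cc(CN(CC2CCCC2)[C@@H](CC(=O)O)c2ccc(Cl)cc2)ccc1OCCN1C(=O)CCC1=O`) gives 3000000 nM. Compound 3 therefore stands level with the other two at the digits shown.

Compound 4 (`CCc1cc(CN(CC2CCCC2)[C@@H](CC(=O)O)c2ccc(Cl)cc2)ccc1OCCN1C(=O)CCC1=O`) departs from compound 3 in one place: methyl in place of hydrogen on a saturated chain carbon bound to an aromatic carbon. This is methyl in place of hydrogen on a saturated chain carbon bound to an aromatic carbon, which also reads as methyl to ethyl.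

For the measured compounds named here, no measured step makes this exact change, so the two available steps bear on it only indirectly. Putting cyclopentyl in place of ethyl on a saturated chain carbon bound to an amine nitrogen gave no change at the digits printed from compound 1 to compound 3 (within the scatter). Going from an undefined to a defined stereocentre at a saturated chain carbon gave no change at the digits printed from compound 2 to compound 3 (within the scatter).

Compound 3, at 3000000 nM, is thus joined to both neighbours by steps within the scatter. On that basis, the expected step in this assay is no change at the digits printed from compound 3 to compound 4 (within the scatter), with none expected beyond the scatter. For compound 4 the estimated solubility is 3000000 nM, with an expected range from 1500000 nM to 3500000 nM.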

Compound 4, solubility: 3000000 nM
Estimate against measurement, compound 4: no gap at the digits printed, and the stated range covers the measured number.
By their numbers in this assay, from the lowest: compounds 1, 2, 3 and 4 (each within the scatter of the next).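

The earlier steps shown here in this assay changed the group on the amine nitrogen and the drawn configuration, but left the saturated chain carbon bound to an aromatic carbon untouched. Methyl to ethyl at that place now gives no change at the digits printed from compound 3 to compound 4 (within the scatter), so a step at a third place in the series also stays within the scatter, and all four compounds remain level at the digits printed. Nothing in the information available accounts for this result.

The compounds shown leave open whether a longer chain, a hydroxyl or an amine at this same place would also stay level with compound 4 in this assay, as one added methyl is the only change tested there. Also open is what a primary amide in place of the carboxylic acid would give, as all four compounds carry that acid and none of the steps shown alters it.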